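A few compounds are considered here, and "the series" means these few. Any claim that something is new, unique, unknown or untested is made for them only; others in the source may bear on it.

Within the data shown here, compound 1 `CN1CCN(CC(=O)O[C@@H]2C[C@@H]3CC[C@@]2(C)C3(C)C)CC1` is one of only two compounds measured in an ADME assay on HEK-293T cells (Homo sapiens) for cytotoxicity, read by MTT assay, with a stated time of 48 h (a lower number here means that less compound is tolerated, a higher number that more compound is tolerated), where compound 1 gives 313000 nM. Among the measured compounds shown here, its single neighbour, compound 2 `CCOC(=O)N1CCN(CC(=O)O[C@@H]2C[C@@H]3CC[C@@]2(C)C3(C)C)CC1`, gives 227000 nM in this assay, and the step of a 1.4-fold lower number from compound 1 to compound 2 (0.14 log units; within the scatter) lies within the scatter. Compound 3 `CCN(CC)CC(=O)O[C@@H]1C[C@@H]2CC[C@@]1(C)C2(C)C` differs from compound 1 by diethylamino in place of 4-methylpiperazin-1-yl on a saturated chain carbon bound to a carbonyl carbon. For the measured compounds named here, that single measured step touched only the substituent on the ring nitrogen, whereas here the ring itself gives way to an open chain, so no measured step bears directly on the change. He therefore expects no movement beyond the scatter in this assay, a step of a 1.0-fold lower number from compound 1 to compound 3 (0.02 log units; within the scatter). For compound 3 he estimates 300000 nM, in a range from 140000 nM to 640000 nM.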

Compound 3, half-maximal cytotoxic concentration: 344000 nM
Beside the measured number, compound 3's estimate is 1.1-fold (0.06 log units) below it; the measured number falls inside the stated range.
By their numbers in this assay, from the lowest: compounds 2, 1 and 3 (each within the scatter of the next).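

The step in this assay is a 1.1-fold higher number from compound 1 to compound 3 (0.04 log units; within the scatter), so at this saturated chain carbon bound to a carbonyl carbon, an open diethylamino group can take the place of the whole 4-methylpiperazin-1-yl ring without a shift beyond the scatter. The earlier step showed this only for a change of the substituent on the ring nitrogen, with the ring kept. No measurement is available to explain this result. Going by these compounds, whether a morpholine ring, a primary amine or a carboxylic acid at this place would move the number beyond the scatter remains open.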